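From propyl to butyl on the shared core

The source may report more compounds than this note shows. Statements on the series, on what has been measured and on what is new or still open speak of the compounds shown alone.

Values in an ADME assay on RAW264.7 cells (Mus musculus) for cytotoxicity, read by MTT assay, with a stated time of 24 h, in the presence of a further agent that is not named here (a lower number here means a stronger inhibitor, a higher number a weaker inhibitor), each one a limit:
Compound 1 `COc1cc(OC)c2c(c1)C(C(O)c1ccc(O)cc1)OC2=O`: > 40000 nM
Compound 2 `COc1ccc(C(O)C2OC(=O)c3c(OC)cc(OC)cc32)cc1`: > 40000 nM
Compound 3 `CCCOc1ccc(C(O)C2OC(=O)c3c(OC)cc(OC)cc32)cc1`: > 40000 nM

Compound 3 gives > 40000 nM, which is a limit and not a number. It stands with the other two compounds at the limit of > 40000 nM in this assay, at which 3 of the 3 values shown sit. Compound 4 `CCCCOc1ccc(C(O)C2OC(=O)c3c(OC)cc(OC)cc32)cc1` differs from compound 3 by methyl in place of hydrogen on a saturated chain carbon, three bonds along the chain from an oxygen on an aromatic ring, so propyl becomes butyl. The closest measured change is a step that the two limits leave unreadable from compound 2 to compound 3. The changes a step that the two limits leave unreadable from compound 1 to compound 2 and a step that the two limits leave unreadable from compound 1 to compound 3 give no size either. With no readable step to draw on, compound 4 is expected to remain at the limit, with no change beyond the scatter. The expected step is a step that the limit leaves unreadable from compound 3 to compound 4. Compound 4 is estimated at 45000 nM. The estimated range for compound 4 runs from 25000 nM to 80000 nM.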

Compound 4, half-maximal inhibitory concentration: > 40000 nM
Compound 4 was reported as a limit; the forecaster's own chance of this, stated with the estimate: 85%; the middle value is on the limit's open side.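

In this assay compound 4 gives > 40000 nM, a limit, so its steps from compound 1, compound 2 and compound 3 cannot be read. Whether any group on that aromatic oxygen changes the value stays open, with every compound shown at one place: the limit of > 40000 nM in this assay, at which 4 of the 4 values shown sit.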